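A few compounds are considered here, and "the series" means these few. Any claim that something is new, unique, unknown or untested is made for them only; others in the source may bear on it.

Among the measured compounds shown here, compound 2 `CC(C)(NC(=O)NCc1ccc2[nH]c(=O)c(-c3nccs3)c(CCc3ccccc3)c2c1)c1ccccc1` is the only compound with a definite number in a functional assay on CHO cells for antagonist activity at adenosine receptor A2b (Homo sapiens), read by cAMP accumulation, with stated times of 15 min and 1 h (a lower number here means a stronger inhibitor, a higher number a weaker inhibitor), where compound 2 gives 17 nM. Compound 1 `Cn1c(=O)c(S(C)(=O)=O)c(CCc2ccccc2)c2cc(OCC(=O)NCc3ccc(Cl)c(Cl)c3)ccc21` yields only a limit in this assay, > 5000 nM, which is not a number; this is the limit of > 5000 nM in this assay, at which 1 of the 2 values shown sits. Compound 3 `O=C(CCc1ccccc1)NCc1ccc2[nH]c(=O)c(-c3nccs3)c(CCc3ccccc3)c2c1` shares the core of compound 2 and differs by phenethyl in place of (1-methyl-1-phenylethyl)amino on a carbonyl carbon. For the measured compounds named here, no measured pair shows a change of this kind, so the expected step of a 3.5-fold higher number from compound 2 to compound 3 (0.55 log units; beyond the scatter) is taken to go beyond the scatter toward weaker inhibition, though not far. Compound 3 is therefore estimated at 60 nM, within a range from 15 nM to 300 nM.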

Compound 3, inhibition constant: 1930 nM
For compound 3 the middle estimate is 32-fold (1.51 log units) below the measured one, and the stated range ends below it.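

In this assay, phenethyl in place of (1-methyl-1-phenylethyl)amino on a carbonyl carbon gives a 110-fold higher number from compound 2 to compound 3 (2.06 log units; beyond the scatter), so this position is far from indifferent to what it carries. The group that leaves holds a nitrogen and a hydrogen-bond donor, and the group that enters holds neither. The assay also has an upper end to what it reports as a number: the limit of > 5000 nM in this assay, at which 1 of the 3 values shown sits.

This single step cannot separate the loss of the nitrogen from the loss of the two methyl groups. A benzylamino group on the same carbonyl carbon would bear on that question, and so would an anilino group.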